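Aryl ketone variation on the shared core: compound 3

A few compounds are considered here, and "the series" means these few. Any claim that something is new, unique, unknown or untested is made for them only; others in the source may bear on it.

Two members of the series have numbers in a functional assay on MCF7 cells (Homo sapiens) for cytotoxicity, read by MTT assay, with a stated time of 48 h; a lower number here means a stronger inhibitor, a higher number a weaker inhibitor. Compound 1 `COc1cc(-c2nnc3n2NC(c2ccco2)C(C(=O)c2ccccc2F)S3)cc(OC)c1OC` gives 94800 nM. Compound 2 `COc1cc(-c2nnc3n2NC(c2ccco2)C(C(=O)c2ccc(O)cc2)S3)cc(OC)c1OC` gives 88900 nM. Among the compounds with values here, the only measured step, a 1.1-fold lower number from compound 1 to compound 2 (0.03 log units; within the scatter), lies within the scatter, so compound 2 is not separated from compound 1; it simply holds the lower of the two numbers.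

Compound 3 `COc1cc(-c2nnc3n2NC(c2ccco2)C(C(=O)c2cccc(Br)c2)S3)cc(OC)c1OC` differs from compound 2 by 3-bromophenyl in place of 4-hydroxyphenyl on a carbonyl carbon. Within the data shown here, no measured step covers the exchange of 4-hydroxyphenyl for 3-bromophenyl on this carbonyl carbon. Among the measured compounds shown here, the single step that alters the same aryl group, from 2-fluorophenyl to 4-hydroxyphenyl, moved nothing beyond the scatter, which gives no ground to expect movement here either. For compound 3 the expected step is therefore a 1.0-fold higher number from compound 2 to compound 3 (0.01 log units; within the scatter), none beyond the scatter. Compound 3 is estimated at 90000 nM in this assay, with a range from 40000 nM to 200000 nM.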

Compound 3, half-maximal inhibitory concentration: 91800 nM
The estimate for compound 3 lay 1.0-fold (0.01 log units) below the measured number; measured number inside the range.
By their numbers in this assay, from the lowest: compounds 2, 3 and 1 (each within the scatter of the next).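

In this assay, the series reads a 1.0-fold higher number from compound 2 to compound 3 (0.01 log units; within the scatter) and a 1.0-fold lower number from compound 1 to compound 3 (0.01 log units; within the scatter), so compound 1, compound 2 and compound 3 remain unseparated. The exchange on this carbonyl carbon removes the 1 hydrogen-bond donor and 1 hydrogen-bond acceptor of 4-hydroxyphenyl and brings in 3-bromophenyl with neither, yet the step stays within the scatter, so among these three aryl ketones neither those counts nor the change of substituent separates the compounds. No available data account for this lack of separation.

Going by these compounds, whether any group at this position can move the number beyond the scatter remains open. An aminophenyl or carboxyphenyl group, or a longer alkyl chain in place of the aryl ring, would test this.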